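Swapping the N-aryl group on a triazole-bearing chromene

The source may report more compounds than this note shows. Statements on the series, on what has been measured and on what is new or still open speak of the compounds shown alone.

Compound 1 `CCOC(=O)C1=Cc2ccccc2OC1(OCc1cn(CC(=O)Nc2ccccc2Br)nn1)C(F)(F)F`; in a functional assay on DU-145 cells (Homo sapiens) for inhibition, read by MTT assay, with a stated time of 24 h (a higher number here means a weaker inhibitor, a lower number a stronger inhibitor), compound 1 gives > 150000 nM, a limit of the assay rather than a number.
Compound 2 `CCOC(=O)C1=Cc2ccccc2OC1(OCc1cn(CC(=O)Nc2ccccc2F)nn1)C(F)(F)F`; in this assay compound 2 gives 33900 nM.
Compound 3 `CCOC(=O)C1=Cc2ccccc2OC1(OCc1cn(-c2ccc([N+](=O)[O-])cc2)nn1)C(F)(F)F`; in this assay compound 3 gives > 150000 nM, again a limit of the assay rather than a number.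

Compound 3 therefore stands at the weak end of what has been measured: it sits at the limit of > 150000 nM in this assay, at which 2 of the 3 values shown sit, so only a floor on its weakness is known. For the measured compounds named here, the one readable step into it is an at least 4.4-fold higher number from compound 2 to compound 3 (0.64 log units; beyond the scatter), while a step that the two limits leave unreadable from compound 1 to compound 3 cannot be sized because both ends are limits. The step from compound 1 to compound 2, an at least 4.4-fold lower number from compound 1 to compound 2 (0.64 log units; beyond the scatter), concerns a different part of the molecule.

Compound 4 `CCOC(=O)C1=Cc2ccccc2OC1(OCc1cn(-c2cccc(OC)c2)nn1)C(F)(F)F` differs from compound 3 by 3-methoxyphenyl in place of 4-nitrophenyl on an aromatic nitrogen. No measured step changes this group, so the steps shown give no direct guide, and the nearest compounds leave compound 3 unreadable beyond its limit. Compound 4 is expected to stay close to where compound 3 stands, with an at least 1.2-fold lower number from compound 3 to compound 4 (0.09 log units; that floor lies within the scatter) as the guess. The estimate for compound 4 in this assay is 120000 nM, within a range from 30000 nM to 300000 nM.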

Compound 4, half-maximal inhibitory concentration: > 150000 nM
Compound 4: a limit, no number; the forecaster's own chance of this, stated with the estimate: 60%; middle value at least 1.2-fold (0.09 log units) away from the limit.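

In this assay compound 4 gives > 150000 nM, a limit of the assay and not a number, so a second aryl group placed directly on this aromatic nitrogen, this time 3-methoxyphenyl with no nitro group, also yields no readable potency, and the set now gathers at one point: the limit of > 150000 nM in this assay, at which 3 of the 4 values shown sit.

For the compounds shown here, the one step that can be read is an at least 4.4-fold higher number from compound 2 to compound 4 (0.64 log units; beyond the scatter), which shows that the ((2-fluorophenyl)carbamoyl)methyl group of compound 2 cannot be exchanged for 3-methoxyphenyl without a clear loss, as already seen with 4-nitrophenyl. The steps from compound 1 and compound 3 to compound 4 cannot be read, since both ends are limits, and compound 1 goes against any simple rule that the aryl groups alone mark the inactive compounds, for it keeps the carbamoylmethyl chain and still sits at a limit.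

On these data alone, how far compound 3 and compound 4 lie beyond the limit stays unknown, so the 4-nitrophenyl and 3-methoxyphenyl groups cannot be ranked. As far as these compounds go, whether a phenyl ring carrying an amine or a carboxylic acid on this nitrogen would give a readable number remains open.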